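Hydroxamate series: aryl swap on the triazole nitrogen

The source may report more compounds than this note shows. Statements on the series, on what has been measured and on what is new or still open speak of the compounds shown alone.

Compound 1 `O=C(NO)c1ccc(NCc2nc(-c3ccccc3)nn2-c2ccccc2Cl)cc1` is the reference point of this set. Going by the values given here, in an assay on Sf9 cells for inhibition of protein deacetylase HDAC6 (Homo sapiens), read by fluorescence, with a stated time of 40 min, tested at 100 nM (on this read-out lower numbers stand for less inhibition and higher numbers for more inhibition at the one concentration tested (going by the name of the read-out)), compound 1 gives 64.6%, the highest of the three numbers measured so far. Compound 2 `O=C(NO)c1ccc(NCc2nc(-c3cccnc3)nn2-c2ccccc2)cc1` gives 57.7% in this assay, a number within the usual scatter of compound 1, so the two cannot be ranked. Compound 3 `CNC(=O)c1ccc(NCc2nc(-c3ccccc3)nn2-c2ccccc2)cc1` carries a methyl amide where compounds 1 and 2 carry the hydroxamic acid. In this assay compound 3 gives -3.6%, far beyond the scatter below compound 1.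

Compound 4 `Cc1ccc(-n2nc(-c3ccccc3)nc2CNc2ccc(C(=O)NO)cc2)cc1C` has not yet been measured. It differs from compound 1 in one place: 3,4-dimethylphenyl in place of 2-chlorophenyl on an aromatic nitrogen. Among the compounds with values here, no step between two measured compounds isolates this kind of change, so the expectation rests on compounds 1 and 2 alone, whose values in this assay lie within the scatter of one another despite differing on the aryl at this position. The step of a number 6.6 percentage points lower from compound 1 to compound 4 (within the scatter) is therefore expected to be small, in either direction, and likely not beyond the scatter. Compound 4 is estimated at 58% in this assay, with a range from 35% to 75%.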

Compound 4, a percentage reported as inhibition, at one concentration (the size of the read-out at that concentration, not a potency): 53%
Compound 4: middle estimate off by 5 percentage points, on the high side, and the stated range covers the measured number.
By their numbers in this assay, from the lowest: compound 3; then compounds 4, 2 and 1 (each within the scatter of the next, the first and the last beyond it).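

In this assay the aryl on this aromatic nitrogen is not fully interchangeable: 3,4-dimethylphenyl in place of 2-chlorophenyl gives a number 11.6 percentage points lower from compound 1 to compound 4 (beyond the scatter), a modest step and the first single-place change read at this position. The change does not abolish the read-out, as compound 4 still gives 53% with the hydroxamic acid in place. Nothing available here bears on the reason for this step.

On these data alone, this single step swaps the chlorine for two methyl groups and alters where the substituents sit on the phenyl ring, so the contribution of each part stays open. Also open, as far as these compounds go, is how the read-out responds at this position to a phenyl ring bearing an amine or a carboxylic acid, or to a longer chain in place of the aryl.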